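The compounds below may be only part of what the source reports. "The series", "measured", "known", "first", "only" and "open" are said of these compounds alone.

Working notes on the series. Two compounds have numbers in a functional assay on PC-3 cells (Homo sapiens) for cytotoxicity, read by MTT assay, with a stated time of 72 h; on this read-out lower numbers stand for stronger inhibition and higher numbers for weaker inhibition. Compound 1 `[O-][n+]1nc(NCOC2CCCCC2)[n+]([O-])c2ccccc21` gives 3250 nM; compound 2 `CC(C)CCOCNc1n[n+]([O-])c2ccccc2[n+]1[O-]` gives 11100 nM. Among the measured compounds shown here, compound 2 thus stands highest of the two, with compound 1 as its only neighbour, and the one measured step, a 3.4-fold higher number from compound 1 to compound 2 (0.53 log units; beyond the scatter), is the only guide available. Compound 3 `CCCCCCCOCNc1n[n+]([O-])c2ccccc2[n+]1[O-]` is not yet measured. It differs from compound 2 by pentyl in place of isopropyl on a saturated chain carbon, two bonds along the chain from an oxygen on a saturated carbon, which read further out is isopentyl to heptyl. The step from compound 1 to compound 2 bears on it only loosely: it changed the same oxygen-linked group and moved the number modestly. For the measured compounds named here, no measured pair tests a branched chain against a straight one of this length. The expectation for compound 3 is a step of a 1.6-fold lower number from compound 2 to compound 3 (0.20 log units; within the scatter), near the scatter, with a slight lean toward a lower number. Compound 3 is therefore estimated at 7000 nM, range 2500 nM to 20000 nM.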

Compound 3, half-maximal inhibitory concentration: 1210 nM
Beside the measured number, compound 3's estimate is 5.8-fold (0.76 log units) above it; measured number below the stated range.
By their numbers in this assay, from the lowest: compound 3; then compound 1; then compound 2.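

In this assay, pentyl in place of isopropyl on a saturated chain carbon, two bonds along the chain from an oxygen on a saturated carbon, gives a 9.2-fold lower number from compound 2 to compound 3 (0.96 log units; beyond the scatter), so this outer part of the chain matters and a straight heptyl does not behave like a branched isopentyl. Swapping the cyclohexyl ring for an open heptyl chain gives a 2.7-fold lower number from compound 1 to compound 3 (0.43 log units; beyond the scatter), so the higher number of compound 2 cannot be read as applying to open-chain groups in general, and the ring of compound 1 is not needed for the lowest number among these three. Nothing in the data at hand accounts for either step.

Compound 2 and compound 3 differ in both branching and chain length, and the compounds shown do not separate the two. From the compounds shown here alone, it remains open how a longer chain such as decyl, or an amine at the chain end, would read.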